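Swapping Phenyl for Methylcarbamoyl on Compound 3

The source may hold more compounds than are shown below. What is called first, only, known or untested is meant among the compounds shown, and "the series" means these compounds.

In an ADME assay on HeLa cells (Homo sapiens) for cytotoxicity, read by crystal violet staining, with a stated time of 72 h (a lower number here means that less compound is tolerated, a higher number that more compound is tolerated), compound 1 `COC(=O)c1cc(CCCOc2c(C)cc(-c3noc(C(F)(F)F)n3)cc2C)on1` gives 35400 nM, and compound 2 `CCOC(=O)c1cc(CCCOc2ccc(-c3noc(C(F)(F)F)n3)cc2C)on1` gives 35100 nM. Compound 3 `Cc1cc(-c2noc(C(F)(F)F)n2)cc(C)c1OCCCc1cc(-c2ccccc2)no1` gives > 100000 nM, which is a limit of the assay and not a number. Compound 3 therefore has no exact position in this small set.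

Compound 4 `CNC(=O)c1cc(CCCOc2c(C)cc(-c3noc(C(F)(F)F)n3)cc2C)on1` differs from it by methylcarbamoyl in place of phenyl on an aromatic carbon. Among the measured compounds shown here, the one measured step that bears on this change is an at least 2.8-fold higher number from compound 1 to compound 3 (0.45 log units; beyond the scatter), with phenyl in place of methoxycarbonyl on an aromatic carbon. The new change removes the phenyl from that same place and puts back a group with no ring, so the earlier step is expected to run roughly in reverse. It is only a rough guide, since methylcarbamoyl has not been measured here, and a second limit remains possible.

In this assay a lower number is expected, with the estimated size given by an at least 2.2-fold lower number from compound 3 to compound 4 (0.34 log units; beyond the scatter). For compound 4 the estimate is 45000 nM, with an expected range from 15000 nM to 100000 nM.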

Compound 4, half-maximal cytotoxic concentration: > 100000 nM
Compound 4 ended at the assay's limit; the forecaster's own chance of this, stated with the estimate: 20%; at least 2.2-fold (0.34 log units) between middle value and limit.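

In this assay, the place on the five-membered aromatic ring does not need a phenyl for a compound to reach the limit: compound 4, which has no ring there, gives > 100000 nM, a limit of the assay and not a number. With the carbonyl kept and only methylamino in place of methoxy, the result is an at least 2.8-fold higher number from compound 1 to compound 4 (0.45 log units; beyond the scatter), so what is attached to the carbonyl makes a difference beyond the scatter. The step from compound 3 to compound 4 cannot be read, because both compounds stand at the same limit: the limit of > 100000 nM in this assay, at which 2 of the 4 values shown sit.

Going by these compounds, how far compound 3 and compound 4 lie past that limit remains unknown, so they cannot be ranked against each other. Also open, on these data alone, is whether a carboxylic acid or an amide with a longer chain on its nitrogen would reach the limit at this place.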